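The source may hold more compounds than are shown below. What is called first, only, known or untested is meant among the compounds shown, and "the series" means these compounds.

Measured in an assay on isolated protein for displacement of a labelled ligand from metabotropic glutamate receptor 5 (Homo sapiens), with a stated time of 60 min, tested at 1 uM; a lower number here means less inhibition, a higher number more inhibition at the concentration tested (going by the name of the read-out):
compound 1 `Cc1ccc(S(=O)(=O)c2cnc3cc(F)ccc3c2N2CCC(C)CC2)cc1Cl` gives 93%
compound 2 `CC1CCN(c2c(S(=O)(=O)c3ccc(C#N)cc3)cnc3cc(F)ccc23)CC1` gives 83%
compound 3 `CC1CCN(c2c(S(=O)(=O)c3cc(Cl)cc(Cl)c3)cnc3cc(F)ccc23)CC1` gives 87%

Compound 3 lies within the scatter of both others: its nearest neighbour is compound 2 (a number 4 percentage points higher from compound 2 to compound 3 (within the scatter)) and its furthest is compound 1 (a number 6 percentage points lower from compound 1 to compound 3 (within the scatter)), so the three numbers are not separable. Compound 4 `CC1CCN(c2c(S(=O)(=O)c3cc(F)cc(F)c3)cnc3cc(F)ccc23)CC1` is not yet measured; the change from compound 3 is 3,5-difluorophenyl in place of 3,5-dichlorophenyl on a sulfonyl sulfur. Among the measured compounds shown here, the steps that bear on this are the earlier swaps of the aryl on the sulfonyl sulfur: a number 10 percentage points lower from compound 1 to compound 2 (within the scatter), a number 6 percentage points lower from compound 1 to compound 3 (within the scatter) and a number 4 percentage points higher from compound 2 to compound 3 (within the scatter), none beyond the scatter. A further aryl at the same place is therefore expected to change the number by no more than the scatter, an estimated step of a number 3 percentage points lower from compound 3 to compound 4 (within the scatter). Compound 4 is expected to give 84%, estimated range 72% to 94%.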

Compound 4, a percentage reported as inhibition, at one concentration (the size of the read-out at that concentration, not a potency): 77%
Estimate against measurement, compound 4: 7 percentage points above; the measured number falls inside the stated range.
By their numbers in this assay, from the lowest: compounds 4, 2, 3 and 1 (each within the scatter of the next, the first and the last beyond it).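

In this assay the aryl on the sulfonyl sulfur now gives a step beyond the scatter, a modest one: a number 16 percentage points lower from compound 1 to compound 4 (beyond the scatter). Among the compounds shown here, this position is therefore not wholly indifferent to the aryl, yet the other two new steps stay within the scatter, a number 10 percentage points lower from compound 3 to compound 4 (within the scatter) and a number 6 percentage points lower from compound 2 to compound 4 (within the scatter), so only that one pair separates. Nothing available explains this step.

Still open, on these data alone, is whether a methoxy or amino group on the aryl, or a cyclohexyl ring in its place, would move the number further. A single-concentration read-out also leaves the potency of these compounds undefined.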